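The source may hold more compounds than are shown below. What is called first, only, known or untested is meant among the compounds shown, and "the series" means these compounds.

Measured compounds in an ADME assay on Raji cells (Homo sapiens) for cytotoxicity, with a stated time of 72 h; on this read-out lower numbers stand for an effect already at smaller amounts and higher numbers for an effect only at larger amounts of compound:
- compound 1 `Cc1cc(NC(=O)Nc2cccc([N+](=O)[O-])c2)c2ccccc2n1` gives > 25000 nM, which is a limit of the assay and not a number.
- compound 2 `Cc1cc(NC(=O)Nc2cccc(F)c2)c2ccccc2n1` gives > 25000 nM, again a limit of the assay.
- compound 3 `Cc1cc(NC(=O)Nc2ccccc2F)c2ccccc2n1` gives > 25000 nM, also a limit of the assay.

For the measured compounds named here, all three shared values sit at the limit of > 25000 nM in this assay, at which 3 of the 3 values shown sit, so no step among them can be read. From compound 2 to compound 1 the change is nitro in place of fluoro on an aromatic carbon, and the step is a step that the two limits leave unreadable from compound 2 to compound 1. From compound 2 to compound 3 the cores are joined differently, (2-fluorophenyl in place of 3-fluorophenyl on an amide-type nitrogen), and that step is likewise a step that the two limits leave unreadable from compound 2 to compound 3.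

Compound 4 `Cc1cc(NC(=O)Nc2ccccc2[N+](=O)[O-])c2ccccc2n1` is not yet measured in this assay. Its difference from compound 3 is nitro in place of fluoro on an aromatic carbon. This is the same kind of change as from compound 2 to compound 1, but the place differs: there the nitro sits meta to a large group, here ortho to a large group. Since compound 3 shows only a limit, > 25000 nM, and the earlier step of this kind, a step that the two limits leave unreadable from compound 2 to compound 1, is unreadable, the expected step for compound 4 is estimated as a step that the limit leaves unreadable from compound 3 to compound 4, with another limit considered likely. The estimate for compound 4 in this assay is 40000 nM, between 15000 nM and 120000 nM.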

Compound 4, half-maximal effective concentration: > 25000 nM
Compound 4: only a limit was reported; the forecaster's own chance of this, stated with the estimate: 85%; the middle value does not contradict the limit.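

In this assay compound 4 gives > 25000 nM, a limit of the assay and not a number, so the change from compound 3 to compound 4 yields no readable step. The compounds shown leave open at what concentration any of them would have an effect in this assay, and whether nitro and fluoro differ there: the limit of > 25000 nM in this assay, at which 4 of the 4 values shown sit.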